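The compounds below may be only part of what the source reports. "The series", "measured", "known", "first", "only" and "open" are said of these compounds alone.

Compound 1 `N#CCCn1nc(-c2ccc(OCc3ccccc3)cc2)oc1=O` stands as the lower of the two numbers recorded so far in an assay for inhibition of Amine oxidase [flavin-containing] B (Rattus norvegicus); on this read-out higher numbers stand for weaker inhibition and lower numbers for stronger inhibition: compound 1 gives 2.2 nM. For the measured compounds named here, its only measured neighbour is compound 2 `Cc1ccc(COc2ccc(-c3nn(CCC#N)c(=O)o3)cc2)cc1`, which carries a methyl in place of hydrogen on an aromatic carbon; in this assay compound 2 gives 15 nM, and that single change read as a 6.8-fold higher number from compound 1 to compound 2 (0.83 log units; beyond the scatter). Compound 3 `N#CCCCn1nc(-c2ccc(OCc3ccccc3)cc2)oc1=O` has not yet been measured. It differs from compound 1 in one place: cyanomethyl in place of cyano on a saturated chain carbon, two bonds along the chain from an aromatic nitrogen. Going by the values given here, the one measured step concerns the methyl on an aromatic carbon, a different part of the molecule from the chain that is altered here, so it bears only loosely on this change; it shows that a small addition can shift the number by a modest amount. Exchanging cyano for cyanomethyl on the chain is expected to move the number only a little, with a slight weakening judged more likely than a gain, so the estimated step is a 2.0-fold higher number from compound 1 to compound 3 (0.31 log units; beyond the scatter). Compound 3 is therefore expected to give about 4.5 nM in this assay, within a range from 1.5 nM to 14 nM.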

Compound 3, half-maximal inhibitory concentration: 410 nM
The estimate for compound 3 lay 91-fold (1.96 log units) below the measured number; the whole stated range lies below it.
By their numbers in this assay, from the lowest: compound 1; then compound 2; then compound 3.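

In this assay, lengthening the chain from 2-cyanoethyl to 3-cyanopropyl, with the nitrile kept, produces a 190-fold higher number from compound 1 to compound 3 (2.27 log units; beyond the scatter) in one step. For the compounds shown here, that is a far larger move than a 6.8-fold higher number from compound 1 to compound 2 (0.83 log units; beyond the scatter) seen for the methyl on an aromatic carbon, so this chain tolerates much less change than the one earlier step suggested. Nothing available here explains why this longer chain costs so much.

The compounds shown leave open whether a shorter chain such as cyanomethyl, or a chain ending in an amine or a carboxylic acid in place of the nitrile, would keep the low number of compound 1. They also leave open whether 3-cyanopropyl would do the same harm in the methyl-bearing compound 2.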